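The source may hold more compounds than are shown below. What is called first, only, known or untested is meant among the compounds shown, and "the series" means these compounds.

Measured compounds:
- compound 1 `CCN1CCN(CC(=O)Nc2ccc(-c3nc(-c4ccccc4)c(-c4ccccc4)n3C)cc2)CC1`: 4.7%
- compound 2 `CN(C)/C=C/N1CCN(CC(=O)Nc2ccc(-c3nc(-c4ccccc4)c(-c4ccccc4)n3C)cc2)CC1`: 1.2%
- compound 3 `Cn1c(-c2ccc(NC(=O)CN3CCN(Cc4ccccc4)CC3)cc2)nc(-c2ccccc2)c1-c1ccccc1`: 7.2%

Within the data shown here, in a functional assay on MCF7 cells (Homo sapiens) for cytotoxicity, read by MTT assay, with a stated time of 24 h, tested at 0.64 ug/mL (a lower number here means a weaker effect, a higher number a stronger effect of the compound at the concentration tested), compound 3 gives 7.2%, the top of these three numbers, yet a number 2.5 percentage points higher from compound 1 to compound 3 (within the scatter) and a number 6 percentage points higher from compound 2 to compound 3 (within the scatter) both stay within the scatter, so no compound is set apart from the others. Compound 4 `Cc1ccc(CN2CCN(CC(=O)Nc3ccc(-c4nc(-c5ccccc5)c(-c5ccccc5)n4C)cc3)CC2)cc1` differs from compound 3 by methyl in place of hydrogen on an aromatic carbon. Among the measured compounds shown here, the only step reaching this part of the molecule is a number 2.5 percentage points higher from compound 1 to compound 3 (within the scatter), and the remaining steps, a number 3.5 percentage points lower from compound 1 to compound 2 (within the scatter) and a number 6 percentage points higher from compound 2 to compound 3 (within the scatter), were also small. Every change so far around the amine nitrogen in the ring has left the read-out essentially unchanged, so the expected step is a number 0.2 percentage points lower from compound 3 to compound 4 (within the scatter), nothing beyond the scatter. Compound 4 is therefore estimated at 7%, with a range from 1% to 15%.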

Compound 4, a percentage reported as activity, at one concentration (the size of the read-out at that concentration, not a potency): 9.4%
Beside the measured number, compound 4's estimate is 2.4 percentage points below it; the range from low to high includes it.
By their numbers in this assay, from the lowest: compounds 2, 1, 3 and 4 (each within the scatter of the next).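

In this assay, methyl in place of hydrogen on the aromatic carbon of the benzyl group gives a number 2.2 percentage points higher from compound 3 to compound 4 (within the scatter) and so leaves the read-out indistinguishable from the scatter. The larger replacements on the amine nitrogen in the ring, a number 8.2 percentage points higher from compound 2 to compound 4 (within the scatter) and a number 4.7 percentage points higher from compound 1 to compound 4 (within the scatter), stay within the scatter too, leaving compound 4 not set apart from the others. No supporting measurement bears on these small differences.

As far as these compounds go, whether an amine or a carboxylic acid on that aromatic carbon would move the read-out beyond the scatter remains open. So does the effect of a longer chain there in place of methyl.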